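The compounds below may be only part of what the source reports. "The series", "measured", "known", "first", "only" and "open" are said of these compounds alone.

Working notes on the series. For the measured compounds named here, compound 1 `CCCC(=O)N1CC2CC(C1)N2` stands highest of the three numbers so far in an assay on SH-EP1 cells for agonist activity at Neuronal acetylcholine receptor; alpha4/beta2 (Homo sapiens), read by FLIPR and calcium flux (on this read-out higher numbers stand for larger maximal responses and lower numbers for smaller maximal responses), where compound 1 gives 120%. Compound 2 `O=C(C1CC=CC1)N1CC2CC(C1)N2` gives 93% in this assay, and compound 3 `O=C(CC1C=CCC1)N1CC2CC(C1)N2` gives 89%. Going by the values given here, the one single-site step among the measured compounds, cyclopent-2-en-1-yl in place of ethyl on a saturated chain carbon bound to a carbonyl carbon, is a number 31 percentage points lower from compound 1 to compound 3 (beyond the scatter). Compound 4 `O=C([C@@H]1C[C@@H]1F)N1CC2CC(C1)N2` has not been measured; it differs from compound 1 as follows: 2-fluorocyclopropyl in place of propyl on a carbonyl carbon. Among the compounds with values here, the step bearing on this is the one from compound 1 to compound 3, where a ring entered in place of chain carbon and the maximal response fell well beyond the scatter; compound 2, which also carries a ring on the carbonyl carbon, sits lower than compound 1 by a similar margin. A fall beyond the scatter is therefore expected in this assay, with compound 4 estimated at 93%, between 72% and 115%. This estimate means an expected step of a number 27 percentage points lower from compound 1 to compound 4 (beyond the scatter).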

Compound 4, largest response reached (Emax), in percent of the reference or control that the assay uses: 120%
The estimate for compound 4 lay 27 percentage points below the measured number; measured number above the stated range.
By their numbers in this assay, from the lowest: compounds 3 and 2 (each within the scatter of the next); then compounds 1 and 4 (each within the scatter of the next).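

In this assay there is no change at the digits printed from compound 1 to compound 4 (within the scatter), so a ring on the carbonyl carbon does not of itself lower the maximal response: 2-fluorocyclopropyl in place of propyl brings a three-membered ring, a fluorine and two defined stereocentres, and the number holds. The step of a number 31 percentage points lower from compound 1 to compound 3 (beyond the scatter) therefore cannot be read as a general result of putting a ring in place of chain carbon, and compound 4 goes against any such pattern, while compound 2 and compound 3 carry the lower numbers. No measured evidence accounts for the difference among these ring-bearing compounds.

The compounds shown leave open whether the result belongs to the three-membered ring or to the fluorine, as plain cyclopropyl on the carbonyl carbon is not among them. Going by these compounds, the other stereoisomers of 2-fluorocyclopropyl and saturated cyclopentyl are also absent, so the part played by the stereocentres and by ring size stays open.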